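Changing the aryl group on the shared core of compound 1

A few compounds are considered here, and "the series" means these few. Any claim that something is new, unique, unknown or untested is made for them only; others in the source may bear on it.

Compound 1 `O=S(=O)(c1cc(Cl)cc(Cl)c1)c1cnc2c(F)cccc2c1-c1ccc(F)cc1`: 1.01 mL/min
Compound 2 `O=S(=O)(c1ccc(F)c(Cl)c1)c1cnc2c(F)cccc2c1-c1ccc(F)cc1`: 0.19 mL/min

Of the compounds shown here, two have been measured in an ADME assay on microsomes from liver (Homo sapiens) for metabolic stability, tested at 2.5 uM; on this read-out lower numbers stand for slow clearance and higher numbers for fast clearance. Compound 1 gives 1.01 mL/min and stands highest of the two numbers; its nearest neighbour is compound 2, reached by a 5.3-fold lower number from compound 1 to compound 2 (0.73 log units; beyond the scatter), a step made by putting 3-chloro-4-fluorophenyl in place of 3,5-dichlorophenyl on the sulfonyl sulfur.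

Compound 3 `COc1cccc(-c2c(S(=O)(=O)c3cc(Cl)cc(Cl)c3)cnc3c(F)cccc23)c1` is not yet measured. It differs from compound 1 at a different place: 3-methoxyphenyl in place of 4-fluorophenyl on an aromatic carbon. Among the measured compounds shown here, the only measured step concerns the group on the sulfonyl sulfur and leaves the aryl group on the aromatic carbon untouched, so it offers no direct guide to this change. With nothing in the measured data pointing either way, the expectation is a number close to that of compound 1, with any shift likely staying within the usual scatter or only a little beyond it.

For compound 3 in this assay the estimate is 1.3 mL/min, expected to lie between 0.5 mL/min and 3.5 mL/min. That estimate means an expected step of a 1.3-fold higher number from compound 1 to compound 3 (0.11 log units; within the scatter).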

Compound 3, intrinsic clearance in a liver preparation (reported as CLH), per the amount of preparation that the assay uses: 2.31 mL/min
Compound 3: middle estimate off by 1.8-fold (0.25 log units), on the low side; the measured number falls inside the stated range.
By their numbers in this assay, from the lowest: compound 2; then compound 1; then compound 3.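

The aryl group on the aromatic carbon opposite the ring nitrogen turns out to matter in this assay: 3-methoxyphenyl in place of 4-fluorophenyl gives a 2.3-fold higher number from compound 1 to compound 3 (0.36 log units; beyond the scatter). Among the compounds shown here, until now, the only measured change was on the sulfonyl sulfur, a 5.3-fold lower number from compound 1 to compound 2 (0.73 log units; beyond the scatter), so this result shows a second place on the shared core where the read-out responds, and here the change moves the number towards faster clearance rather than slower. No measurement available here explains why this swap raises the number, so the result stands as an observation without a known cause.

This single step changes several things at once, since the fluorine leaves, a methoxy group enters and the substituent sits at a different ring position, and the compounds shown cannot separate these contributions; a plain phenyl, 3-fluorophenyl or 4-methoxyphenyl group at this place would help to pull them apart. As far as these compounds go, it also remains open whether 3-methoxyphenyl would raise the number to a similar extent with the 3-chloro-4-fluorophenyl group of compound 2 on the sulfonyl sulfur.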